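Anilide aryl change in the trifluoromethyl diol amide series

This account rests on a few compounds, and the source may have more. Where it says the series, first, only, none or still open, it means among the compounds named here.

Within the data shown here, compound 2 `O=C(CCCCCCNC(=O)C(O)(O)C(F)(F)F)Nc1ccc(Br)cc1` carries a 4-bromophenyl on the amide-type nitrogen; in a functional assay on HCT-116 cells (Homo sapiens) for inhibition, read by colorimetric assay, with a stated time of 3 days (on this read-out lower numbers stand for stronger inhibition and higher numbers for weaker inhibition), compound 2 gives 3130 nM, the highest of the two numbers so far, with compound 1 `O=C(CCCCCCNC(=O)C(O)(O)C(F)(F)F)Nc1nc2ccccc2s1` nearest, which in this assay gives 2370 nM. Among the measured compounds shown here, the step of a 1.3-fold higher number from compound 1 to compound 2 (0.12 log units; within the scatter) is the only measured step and lies within the scatter. Compound 3 `O=C(CCCCCCNC(=O)C(O)(O)C(F)(F)F)Nc1ccc(-c2ccccc2)cc1` differs from compound 2 by phenyl in place of bromo on an aromatic carbon. For the measured compounds named here, no measured step bears on this change: the one step available swaps the whole aromatic group and does not touch a substituent on a phenyl ring. With nothing comparable to go on, the expected step of a 1.1-fold lower number from compound 2 to compound 3 (0.05 log units; within the scatter) is none beyond the scatter, in either direction. Going by the values given here, compound 3 is therefore estimated at 2800 nM in this assay, with a wide range from 900 nM to 9000 nM because the step of a 1.3-fold higher number from compound 1 to compound 2 (0.12 log units; within the scatter) is the only guide.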

Compound 3, half-maximal inhibitory concentration: 4730 nM
For compound 3 the middle estimate is 1.7-fold (0.23 log units) below the measured one; low and high end bracket the measured number.
By their numbers in this assay, from the lowest: compounds 1, 2 and 3 (each within the scatter of the next).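

In this assay, phenyl in place of bromo on an aromatic carbon, para to a large group, gives a 1.5-fold higher number from compound 2 to compound 3 (0.18 log units; within the scatter), so this first change of a ring substituent, with 6 heavy atoms entering for 1, produces no step beyond the scatter. Together with the change of the whole aryl group, a 1.3-fold higher number from compound 1 to compound 2 (0.12 log units; within the scatter), this means that neither step at this end of the molecule separates the compounds it joins. No available evidence bears on this result.

The compounds shown leave open whether an amine or a carboxylic acid on this aromatic carbon would give a step beyond the scatter. They also leave open whether a longer chain in the shared core would change the read-out more than any substituent here has.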